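Adding a second fluoro to compound 3

The source may hold more compounds than are shown below. What is called first, only, known or untested is meant among the compounds shown, and "the series" means these compounds.

Measured so far in an ADME assay on BJ cells (Homo sapiens) for cytotoxicity, with a stated time of 72 h; a higher number here means that more compound is needed for the effect, a lower number that less compound is needed
- Compound 1 `COc1ccc(-c2nc3ccccc3o2)cc1NC(=O)c1cc([N+](=O)[O-])ccc1Cl` gives > 25000 nM as a limit of the assay
- Compound 2 `O=C(Nc1nc(-c2ccc(Cl)cc2)cs1)c1cc([N+](=O)[O-])ccc1Cl` gives 18000 nM as a number
- Compound 3 `O=C(Nc1nc(-c2cccc(F)c2)cs1)c1cc([N+](=O)[O-])ccc1Cl` gives 24000 nM as a number

Going by the values given here, compound 3 stands level with its one close neighbour, since the only measured step is a 1.3-fold higher number from compound 2 to compound 3 (0.12 log units; within the scatter) and shows no real difference. Compound 1 stays apart, as its entry at the limit of > 25000 nM in this assay, at which 1 of the 3 values shown sits, is a limit and not a number.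

Compound 4 `O=C(Nc1nc(-c2ccc(F)c(F)c2)cs1)c1cc([N+](=O)[O-])ccc1Cl` carries one change, fluoro in place of hydrogen on an aromatic carbon and in words this is fluoro in place of hydrogen on an aromatic carbon, so 3-fluorophenyl becomes 3,4-difluorophenyl. The measured step that bears on this swaps 4-chlorophenyl for 3-fluorophenyl, and at a 1.3-fold higher number from compound 2 to compound 3 (0.12 log units; within the scatter) it stays small. No step beyond the scatter is therefore expected in this assay for the added fluoro. The expected size is a 1.1-fold lower number from compound 3 to compound 4 (0.04 log units; within the scatter) in all. For compound 4 the estimate is 22000 nM with an expected range from 12000 nM to 35000 nM in this readout, and the result may also come back as a limit only.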

Compound 4, half-maximal effective concentration: > 27000 nM
Compound 4: no number, only a limit (the forecaster's own chance of this, stated with the estimate: 35%); middle value at least 1.2-fold (0.08 log units) away from the limit.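

Compound 4 gives a limit and not a number: the limit of > 27000 nM in this assay, at which 1 of the 4 values shown sits.

Going by these compounds alone, with fluoro in place of hydrogen at this spot, ortho to a fluoro group and para to a large group, this assay shows no sign that less compound is needed for the effect, the step being an at least 1.1-fold higher number from compound 3 to compound 4 (0.05 log units; that floor lies within the scatter). Going to 3,4-difluorophenyl in place of 4-chlorophenyl gives the same picture, with an at least 1.5-fold higher number from compound 2 to compound 4 (0.17 log units; that floor lies within the scatter), and both steps are floors, so their true size is unknown and could be larger than printed.

As far as these compounds go, whether an amine or a carboxylic acid at this spot would give a clear number in this assay stays open. From the compounds shown here alone, how far the true value of compound 4 lies past its limit also stays open.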